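Diaryl urea series: varying the terminal aryl group

A few compounds are considered here, and "the series" means these few. Any claim that something is new, unique, unknown or untested is made for them only; others in the source may bear on it.

Working notes on a pyrazole-linked diaryl urea set. In a functional assay on NCI-H23 cells (Homo sapiens) for inhibition, read by sulforhodamine B assay, with a stated time of 48 h, tested at 0.1 uM (on this read-out higher numbers stand for a weaker effect at the one concentration tested and lower numbers for a stronger effect), compound 1 `COc1cc(Cl)cc(-c2nn(-c3cccc(NC(=O)Nc4cc(C(F)(F)F)cc(C(F)(F)F)c4)c3)cc2-c2ccncc2)c1` gives 95% and compound 2 `COc1cc(Cl)cc(-c2nn(-c3cccc(NC(=O)Nc4ccc(Cl)c(Cl)c4)c3)cc2-c2ccncc2)c1` gives 93%. Compound 2 holds the lowest of the two numbers, but its neighbour compound 1 sits only a little higher, a gap within the usual scatter, so the two are read as equivalent; both show only a marginal effect at the single concentration tested.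

Compound 3 `COc1cc(Cl)cc(-c2nn(-c3cccc(NC(=O)Nc4cccc(C(F)(F)F)c4)c3)cc2-c2ccncc2)c1` has not yet been measured. It differs from compound 2 in one place: 3-(trifluoromethyl)phenyl in place of 3,4-dichlorophenyl on an amide-type nitrogen. The replacement sits on the amide-type nitrogen next to the carbonyl carbon. Among the measured compounds shown here, no step between measured compounds exists that isolates this exchange. Given that compound 1 with two trifluoromethyl groups on that ring gives 95%, no step beyond the scatter is expected. In this assay compound 3 is estimated at 94%, within 84% to 102%, so the expected step is a number 1 percentage points higher from compound 2 to compound 3 (within the scatter).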

Compound 3, a percentage reported as activity, at one concentration (the size of the read-out at that concentration, not a potency): 90%
Compound 3: the middle estimate sits 4 percentage points above what was measured, and the stated range covers the measured number.
By their numbers in this assay, from the lowest: compounds 3, 2 and 1 (each within the scatter of the next).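

In this assay, 3-(trifluoromethyl)phenyl in place of 3,4-dichlorophenyl on the amide-type nitrogen gives a number 3 percentage points lower from compound 2 to compound 3 (within the scatter) and thus shows that this exchange of ring substituents does not separate the two compounds. Hydrogen in place of trifluoromethyl on an aromatic carbon gives a number 5 percentage points lower from compound 1 to compound 3 (within the scatter) and adds the first single-place comparison within the trifluoromethyl-bearing pair, with one or two trifluoromethyl groups on that ring reading as equivalent here. No accompanying measurement bears on these results.

The compounds shown leave open whether a terminal ring carrying a dimethylamino group or a carboxylic acid would produce a step beyond the scatter. As far as these compounds go, it also remains open whether compound 1, compound 2 and compound 3 would separate at any other concentration.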